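Will 1H-pyrrol-2-yl alter growth inhibition in compound 3?

The source may report more compounds than this note shows. Statements on the series, on what has been measured and on what is new or still open speak of the compounds shown alone.

In a functional assay on DU-145 cells (Homo sapiens) for inhibition, read by trypan blue exclusion, with a stated time of 96 h (on this read-out lower numbers stand for stronger inhibition of growth and higher numbers for weaker inhibition of growth), compound 1 (`Cc1ccc(S/C(=C/c2cc(Cl)cc(Cl)c2Cl)C(=O)c2ccc(Cl)cc2)cc1`) gives 50000 nM. Compound 2 (`Cc1ccc(S/C(=C/c2sccc2C)C(=O)c2ccc(Cl)cc2)cc1`) gives 50000 nM, which places it level with compound 1. So far, only one measured step bears on the next compound. Putting 3-methylthiophen-2-yl in place of 2,3,5-trichlorophenyl on a double-bonded chain carbon gives no change at the digits printed from compound 1 to compound 2 (within the scatter).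

Compound 3 (`Cc1ccc(S/C(=C/c2ccc[nH]2)C(=O)c2ccc(Cl)cc2)cc1`) keeps the shared core and differs at that same place, with 1H-pyrrol-2-yl in place of 3-methylthiophen-2-yl on a double-bonded chain carbon bound to a double-bonded chain carbon. Among the compounds with values here, no measured compound carries this new group, and a single step is thin evidence. Within the data shown here, still, the one exchange seen at this place left the read-out level, as no change at the digits printed from compound 1 to compound 2 (within the scatter) shows. The expectation is therefore no step beyond the scatter in this assay, and so no direction can be favoured. The expected size of the change is no change at the digits printed from compound 2 to compound 3 (within the scatter). For compound 3 the estimated value is 50000 nM, with an expected range from 15000 nM to 100000 nM.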

Compound 3, concentration for 50% growth inhibition: 10000 nM
For compound 3 the middle estimate is 5.0-fold (0.70 log units) above the measured one, and the stated range ends above it.
By their numbers in this assay, from the lowest: compound 3; then compounds 1 and 2 (each within the scatter of the next).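

In this assay, the group on this double-bonded chain carbon turns out to matter: the earlier exchange left the number level, whereas 1H-pyrrol-2-yl gives a 5.0-fold lower number from compound 2 to compound 3 (0.70 log units; beyond the scatter) and a 5.0-fold lower number from compound 1 to compound 3 (0.70 log units; beyond the scatter). The exchange from 3-methylthiophen-2-yl keeps one five-membered aromatic ring with 1 hetero atom, yet nitrogen replaces sulfur, the methyl group is gone, and 1 hydrogen-bond donor enters where the leaving group has none, so several features change in a single step. Nothing measured here explains why this exchange lowers the number.

The compounds shown leave open which of these features goes with the lower number, and a 1-methyl-1H-pyrrol-2-yl group or a thiophen-2-yl group without the methyl at this place would begin to separate them. They also leave open whether an imidazol-2-yl group, which has a second ring nitrogen, would lower the number further or bring it back to the level of compound 1 and compound 2.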